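A few compounds are considered here, and "the series" means these few. Any claim that something is new, unique, unknown or untested is made for them only; others in the source may bear on it.

Three compounds have been measured in a functional assay on A549 cells (Homo sapiens) for antiproliferative activity, read by MTT assay, with a stated time of 48 h; a lower number here means a stronger inhibitor, a higher number a weaker inhibitor:

Compound 1 `CC(C)=CCC[C@]1(C)/C=C/[C@@H](OC(=O)C=C(C)C)[C@](C)(O)/C=C/C(=O)/C(CCl)=C\C1`: 150 nM
Compound 2 `CC(C)=CCC[C@]1(C)/C=C/[C@@H](OC(=O)C=C(C)C)[C@](C)(O)/C=C/C(=O)/C(CN(C(C)C)C(C)C)=C\C1`: 650 nM
Compound 3 `CC(C)=CCC[C@]1(C)/C=C/[C@@H](OC(=O)C=C(C)C)[C@](C)(O)/C=C/C(=O)/C(CN2CCCC2)=C\C1`: 180 nM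

Among these three numbers compound 3 holds the second highest; its value and that of compound 1 sit within the scatter of each other, a 1.2-fold higher number from compound 1 to compound 3 (0.08 log units; within the scatter), while compound 2 stands apart, a 3.6-fold lower number from compound 2 to compound 3 (0.56 log units; beyond the scatter). Compound 4 `CC(C)=CCC[C@]1(C)/C=C/[C@@H](OC(=O)C=C(C)C)[C@](C)(O)/C=C/C(=O)/C(C(=O)N(C)C)=C\C1` differs from compound 3 in one place: dimethylcarbamoyl in place of (pyrrolidin-1-yl)methyl on a double-bonded ring carbon. The three measured steps all exchange the group on the saturated chain carbon bound to a double-bonded ring carbon, and the largest of them, a 4.3-fold higher number from compound 1 to compound 2 (0.64 log units; beyond the scatter), was only modest. The step to compound 4 goes further, since the whole (pyrrolidin-1-yl)methyl group leaves and dimethylcarbamoyl takes its place directly on the double-bonded ring carbon, so the measured steps bear on it only loosely. On their showing, changes at this site have cost nothing to a modest amount in this assay, and a modest weakening is expected for compound 4, a 2.8-fold higher number from compound 3 to compound 4 (0.44 log units; beyond the scatter). Compound 4 is therefore estimated at 500 nM, with a range from 180 nM to 1500 nM.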

Compound 4, half-maximal inhibitory concentration: 2700 nM
Beside the measured number, compound 4's estimate is 5.4-fold (0.73 log units) below it; measured number outside the range, above it.
By their numbers in this assay, from the lowest: compounds 1 and 3 (each within the scatter of the next); then compound 2; then compound 4.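

In this assay, moving to dimethylcarbamoyl on this double-bonded ring carbon brings the first large loss at this site (a 15-fold higher number from compound 3 to compound 4 (1.18 log units; beyond the scatter); an 18-fold higher number from compound 1 to compound 4 (1.26 log units; beyond the scatter)). Even compound 2, the weakest of the earlier compounds, loses further (a 4.2-fold higher number from compound 2 to compound 4 (0.62 log units; beyond the scatter)), so this site tolerates chloromethyl and (pyrrolidin-1-yl)methyl far better than dimethylcarbamoyl, and the earlier exchanges on the saturated chain carbon gave no sign of a loss this size. No measurement shown here gives a reason for this loss.

The compounds shown do not separate the effect of a carbonyl on the ring carbon from that of removing the saturated chain carbon. A (dimethylamino)methyl group or a (pyrrolidin-1-yl)carbonyl group at this carbon would test each of these more directly.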